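Swapping trifluoromethyl for trifluoromethoxy on a spiro urea

The compounds below may be only part of what the source reports. "The series", "measured", "known", "first", "only" and "open" are said of these compounds alone.

Measured so far:
compound 1, `Cc1noc(NC(=O)N2CCC3(CC2)CC(c2cccc(OC(F)(F)F)c2)C3)c1C`, 1 mg/kg
compound 2, `Cn1nnnc1NC(=O)N1CCC2(CC1)CC(c1cccc(C(F)(F)F)c1)CO2`, 1 mg/kg

In a functional assay on the whole organism for inhibition, with Rattus norvegicus as the target, with a stated time of 3 h, at a dose of 3 mg/kg by the oral route (on this read-out higher numbers stand for an effect only at larger amounts of compound and lower numbers for an effect already at smaller amounts), compound 1 gives 1 mg/kg, and compound 2 gives 1 mg/kg. Compound 2 therefore stands level with compound 1 at the digits shown, and the two values sit within the usual scatter of each other, so nothing can be read into their order.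

Compound 3, `Cn1nnnc1NC(=O)N1CCC2(CC1)CC(c1cccc(OC(F)(F)F)c1)CO2`, has not yet been measured. It differs from compound 2 by one change: trifluoromethoxy in place of trifluoromethyl on an aromatic carbon. The same trifluoromethoxy group is already present in compound 1, and compound 1 gives 1 mg/kg, a value level with compound 2. Going by the values given here, no step between measured compounds is available for this change, so the expectation rests on that comparison alone. In this assay the step from compound 2 to compound 3 is expected to be no change at the digits printed from compound 2 to compound 3 (within the scatter), that is, none beyond the scatter.

Compound 3 is thus estimated to give 1 mg/kg, within a range of 0.3 mg/kg to 3 mg/kg.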

Compound 3, minimum effective dose: 0.1 mg/kg
The estimate for compound 3 lay 10-fold (1.00 log units) above the measured number, outside the stated range (below it).
By their numbers in this assay, from the lowest: compound 3; then compounds 1 and 2 (each within the scatter of the next).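

In this assay, putting trifluoromethoxy in place of trifluoromethyl on the aromatic carbon gives a 10-fold lower number from compound 2 to compound 3 (1.00 log units; beyond the scatter), so one group at this place, meta to a large group, can shift the minimum effective dose beyond the usual scatter. Compound 1 and compound 2 differ in more than one place, so their level values could not isolate this change, whereas compound 2 and compound 3 differ only in this group. Nothing measured here accounts for the size of the step.

From the compounds shown here alone, this is a single pair, so it remains open whether trifluoromethyl and trifluoromethoxy would differ in the same way on the core of compound 1. Going by these compounds, how other groups at this place, such as a nitrile or a methoxy, would read in this assay also remains open.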